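A few compounds are considered here, and "the series" means these few. Any claim that something is new, unique, unknown or untested is made for them only; others in the source may bear on it.

Three chalcones carrying an aryl piperazine on the shared core have been examined in a functional assay on the whole organism (strain Kunming) for inhibition, with Mus musculus as the target, with a stated time of 1 h, at a dose of 40 mg/kg by the oral route; a lower number here means less inhibition, a higher number more inhibition at the dose given (going by the name of the read-out). Compound 1 `O=C(/C=C/c1ccccc1)c1ccc(N2CCN(c3ccc([N+](=O)[O-])cc3)CC2)cc1` gives 55.4%. Compound 2 `COc1cccc(N2CCN(c3ccc(C(=O)/C=C/c4ccccc4)cc3)CC2)c1` gives 16%, and compound 3 `Cc1ccc(N2CCN(c3ccc(C(=O)/C=C/c4ccccc4)cc3)CC2)cc1` gives 2.85%, the lowest of the three numbers, with the step of a number 13.2 percentage points lower from compound 2 to compound 3 (beyond the scatter) and the step of a number 52.6 percentage points lower from compound 1 to compound 3 (beyond the scatter) both beyond the scatter. Compound 4 `O=C(/C=C/c1ccccc1)c1ccc(N2CCN(c3ccccc3)CC2)cc1` differs from compound 3 by hydrogen in place of methyl on an aromatic carbon. Among the measured compounds shown here, no measured step removes a methyl outright; the nearest is the step of a number 52.6 percentage points lower from compound 1 to compound 3 (beyond the scatter), which changed the same aromatic carbon, while the step of a number 13.2 percentage points lower from compound 2 to compound 3 (beyond the scatter) exchanged the whole aryl group. Since compound 3 already sits at the bottom, a step of a number 9.2 percentage points higher from compound 3 to compound 4 (within the scatter) is expected, and compound 4 is estimated at 12%, between 0% and 35%.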

Compound 4, a percentage reported as inhibition, in the whole organism at one dose (the size of the read-out at that dose, not a potency): 3.71%
For compound 4 the middle estimate is 8.3 percentage points above the measured one; the measured number falls inside the stated range.
By their numbers in this assay, from the lowest: compounds 3 and 4 (each within the scatter of the next); then compound 2; then compound 1.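

With a number 0.9 percentage points higher from compound 3 to compound 4 (within the scatter) the methyl on this aromatic carbon makes no difference that can be read, so phenyl and 4-methylphenyl stand together at the bottom of the series. With a number 12.3 percentage points lower from compound 2 to compound 4 (beyond the scatter) and a number 51.7 percentage points lower from compound 1 to compound 4 (beyond the scatter) the methoxy and above all the nitro emerge as the groups whose replacement by hydrogen moves the number beyond the scatter, which the methyl does not do. Nothing available explains these differences. Going by these compounds, whether an amine, a carboxylic acid or a chlorine on this carbon would approach compound 1 stays open, as does whether nitro elsewhere on the ring would do so.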